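Cytotoxicity on Colon Cells: Following One Amide Swap

The source may report more compounds than this note shows. Statements on the series, on what has been measured and on what is new or still open speak of the compounds shown alone.

compound 1 `Cc1cccc(NC(=O)c2cccc(/C=C3\CC(=O)N(c4ccccc4)C3=O)c2)c1` — a limit of the assay, > 100000 nM
compound 2 `CCc1cccc(NC(=O)c2cccc(/C=C3\CC(=O)N(c4ccccc4)C3=O)c2)c1` — a limit of the assay, > 100000 nM
compound 3 `CCCCCN1C(=O)C/C(=C\c2cccc(C(=O)Nc3cccc(CC)c3)c2)C1=O` — a limit of the assay, > 100000 nM

Three compounds sharing one core were tested in an ADME assay on NCM460 cells (Homo sapiens) for cytotoxicity, read by MTT assay, with a stated time of 72 h; on this read-out higher numbers stand for weaker inhibition and lower numbers for stronger inhibition. None gave a number: the limit of > 100000 nM in this assay, at which 3 of the 3 values shown sit. Compound 2 therefore stands at the limit of the assay, with nothing to separate it from compound 1 or compound 3. The step that the two limits leave unreadable from compound 1 to compound 2 and the step that the two limits leave unreadable from compound 2 to compound 3 are both unreadable, because the limit of > 100000 nM in this assay, at which 3 of the 3 values shown sit, leaves no measured value on either side.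

Compound 4 `O=C(NCC1CCCCC1)c1cccc(/C=C2\CC(=O)N(c3ccccc3)C2=O)c1` is not yet measured. Compared with compound 2, the change is cyclohexylmethyl in place of 3-ethylphenyl on an amide-type nitrogen. Going by the values given here, no measured step touches this part of the molecule, and the two steps that exist give no size at all. Among the compounds with values here, the only guide is that every compound so far sits at the limit.

Compound 4 is therefore expected to sit at that same limit, a step of a number no higher from compound 2 to compound 4 (the limit leaves the size open) meaning no change beyond the scatter. The estimate for compound 4 is 100000 nM, in the range 40000 nM to 250000 nM.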

Compound 4, half-maximal inhibitory concentration: > 100000 nM
Compound 4 ended at the assay's limit (the forecaster's own chance of this, stated with the estimate: 85%); the middle value lies on the limit itself.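

Neither the step from compound 2 to compound 4 nor the step from compound 1 to compound 4 can be read, because all four compounds give the same limit rather than a number: the limit of > 100000 nM in this assay, at which 4 of the 4 values shown sit.

The compounds shown leave open how far apart they truly lie in this assay, and which change, if any, would give a measurable value.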